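This account rests on a few compounds, and the source may have more. Where it says the series, first, only, none or still open, it means among the compounds named here.

Compound 1, with structure `CNC(=O)c1cc(C(=O)N[C@H]2CC[C@H](O)CC2)n([C@@H](C)c2ccc(Cl)cc2)n1`, and compound 2, with structure `CNC(=O)c1cc(C(=O)N[C@H]2CC[C@H](O)CC2)n([C@@H](C)c2ccccc2)n1`, share one core, and compound 2 differs from compound 1 by hydrogen in place of chloro on an aromatic carbon. In an ADME assay for permeability (on this read-out higher numbers stand for higher permeability and lower numbers for lower permeability), compound 1 gives 180 nm/s, while compound 2 gives 80 nm/s, so that removing the chloro made a 2.3-fold lower number from compound 1 to compound 2 (0.35 log units; beyond the scatter). Compound 3, with structure `CNC(=O)c1cc(C(=O)N[C@H]2[C@@H]3C[C@@H](O)C[C@@H]32)n([C@@H](C)c2cccc(Cl)c2)n1`, is built on a different core; the difference between the two cores is not broken down here. In this assay compound 3 gives 197 nm/s, and against compound 1 that gap lies within the usual scatter of the assay, so no order between the two can be claimed. Compound 4, with structure `CNC(=O)c1cc(C(=O)N[C@H]2[C@@H]3C[C@@H](O)C[C@@H]32)n([C@@H](C)c2ccccc2)n1`, has not yet been measured in this assay. It differs from compound 3 by hydrogen in place of chloro on an aromatic carbon. Among the measured compounds shown here, this is the same kind of change as the one from compound 1 to compound 2, but not the same: in compound 1 the chloro sits para to a large group, whereas in compound 3 it sits meta to a large group. For the measured compounds named here, the only measured example of this kind of change is the step from compound 1 to compound 2, which made a 2.3-fold lower number from compound 1 to compound 2 (0.35 log units; beyond the scatter). A step of about that size is therefore expected, namely a 2.2-fold lower number from compound 3 to compound 4 (0.34 log units; beyond the scatter), resting on that single example and carrying the uncertainty of a changed position. Compound 4 is expected to give about 90 nm/s in this assay, most likely between 50 nm/s and 160 nm/s.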

Compound 4, apparent permeability: 61 nm/s
Compound 4: the middle estimate sits 1.5-fold (0.17 log units) above what was measured; the range from low to high includes it.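

On the core of compound 3, hydrogen in place of chloro gave a 3.2-fold lower number from compound 3 to compound 4 (0.51 log units; beyond the scatter), and the earlier step on the core of compound 1 points the same way, with no difference in size that can be claimed: the same change on two cores in this assay, a 2.3-fold lower number (0.35 log units; beyond the scatter) from compound 1 to compound 2 and a 3.2-fold lower number (0.51 log units; beyond the scatter) from compound 3 to compound 4, 1.4-fold (0.16 log units) apart, within the scatter of two such steps

So in this assay this change carries over from one core to the other in direction and, within the scatter, in size, although that rests on only two pairs of compounds. It does not show that the step is the same wherever the chloro sits, since the chloro occupies a different place on the ring in compound 1 and compound 3, and two pairs cannot separate the effect of the core from that of the position. Among the compounds shown here, with no chloro on either compound, the two cores can be set side by side, and a 1.3-fold lower number from compound 2 to compound 4 (0.12 log units; within the scatter) allows no order between them.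

The compounds shown leave open how the two cores compare when each carries the chloro at the same place on the ring. They also leave open whether other groups in the chloro's place, such as fluoro, methyl or methoxy, would carry across the two cores in the same way.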